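The source may hold more compounds than are shown below. What is called first, only, known or untested is meant among the compounds shown, and "the series" means these compounds.

Working notes on the series.

Of the compounds shown here, two of the shared core have numbers so far. Compound 1 `N#CC1=C(N)N(c2ccc(S(N)(=O)=O)cc2)C2=C(CCCC2)C1c1ccccc1O` gives 10% in a functional assay on Ehrlich cells (Mus musculus) for cytotoxicity, read by trypan blue exclusion, with a stated time of 2 h, tested at 10 ug/mL; a higher number here means a stronger effect of the compound at the concentration tested, a lower number a weaker effect. Compound 2 `COc1ccccc1C1C(C#N)=C(N)N(c2ccc(S(N)(=O)=O)cc2)C2=C1CCCC2` gives 30% in this assay. For the measured compounds named here, the one step between them, a number 20 percentage points higher from compound 1 to compound 2 (beyond the scatter), is the only measured step in the set. On these two numbers compound 2 stands highest; its nearest neighbour is compound 1, which lies lower by a step beyond the scatter.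

The next compound to be measured is compound 3 `N#CC1=C(N)N(c2ccc(S(N)(=O)=O)cc2)C2=C(CCCC2)C1c1cccs1`. Its difference from compound 2 is thiophen-2-yl in place of 2-methoxyphenyl on a saturated ring carbon. Going by the values given here, no measured step speaks to this exchange: the step of a number 20 percentage points higher from compound 1 to compound 2 (beyond the scatter) concerns only a methyl in place of hydrogen on an oxygen, and the 2-methoxyphenyl group that carried that oxygen is now gone as a whole. Without a comparable step, the expected size in this assay is only a weak guess; a drop no larger than the scatter is expected, written as a number 10 percentage points lower from compound 2 to compound 3 (within the scatter). For compound 3 the estimate in this assay is therefore 20%, with a range from 5% to 40%.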

Compound 3, a percentage reported as activity, at one concentration (the size of the read-out at that concentration, not a potency): 0%
Estimate against measurement, compound 3: 20 percentage points above; measured number below the stated range.
By their numbers in this assay, from the lowest: compounds 3 and 1 (each within the scatter of the next); then compound 2.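

The saturated ring carbon next to the ring atom that bears a cyano group responds to exchange of the whole aromatic group in this assay: a number 30 percentage points lower from compound 2 to compound 3 (beyond the scatter), so the gain seen with the methyl on the oxygen does not carry over to thiophen-2-yl. Set against the 2-hydroxyphenyl group, the same thiophen-2-yl gives a number 10 percentage points lower from compound 1 to compound 3 (within the scatter), so among these three compounds only the 2-methoxyphenyl group of compound 2 stands apart, while compound 1 and compound 3 cannot be separated. Nothing measured here speaks to the reason for this difference.

On these data alone, it remains open whether an unsubstituted phenyl, a furan-2-yl, or an ethoxy group in place of the methoxy group would stay with compound 2 or with compound 1 and compound 3. Each read-out also comes from a single concentration, which gives no potency, and the shared core has so far been varied only at this one carbon.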